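Swapping the aryl group: an indole enters the series

This account rests on a few compounds, and the source may have more. Where it says the series, first, only, none or still open, it means among the compounds named here.

Three compounds have been measured in an ADME assay (liver) for metabolic stability, with Liver microsome (Homo sapiens) as the target, using microsomes and NADPH, with a stated time of 30 min, tested at 1 uM; a higher number here means faster removal of the compound, a lower number slower removal:

Compound 1 `Cc1csc(-c2cc(C(O)(C(F)(F)F)C(F)(F)F)cnc2N2CCN(S(=O)(=O)c3ccc(N)nc3)CC2)c1`: 29 mL.min-1.g-1
Compound 2 `Nc1ccc(S(=O)(=O)N2CCN(c3ncc(C(O)(C(F)(F)F)C(F)(F)F)cc3-c3cccc(F)c3)CC2)cn1`: 25 mL.min-1.g-1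
Compound 3 `Nc1ccc(S(=O)(=O)N2CCN(c3ncc(C(O)(C(F)(F)F)C(F)(F)F)cc3-c3cnccc3F)CC2)cn1`: 17 mL.min-1.g-1

Compound 3 gives the lowest of the three numbers in this assay, but the gaps are small: a 1.5-fold lower number from compound 2 to compound 3 (0.17 log units; within the scatter) and a 1.7-fold lower number from compound 1 to compound 3 (0.23 log units; within the scatter), both within the scatter, so the three cannot be ranked.

Compound 4 `Nc1ccc(S(=O)(=O)N2CCN(c3ncc(C(O)(C(F)(F)F)C(F)(F)F)cc3-c3cc4ccccc4[nH]3)CC2)cn1` differs from compound 3 in one place: 1H-indol-2-yl in place of 4-fluoropyridin-3-yl on an aromatic carbon. All three steps measured so far exchange the group at this same position, and each of them, including a 1.2-fold lower number from compound 1 to compound 2 (0.06 log units; within the scatter), stayed within the scatter. Those steps bear on the new change, yet none of them introduces a group with a hydrogen-bond donor or a second ring, so they only loosely constrain it. The expectation is therefore no step beyond the scatter, and compound 4 is estimated to show a 1.3-fold higher number from compound 3 to compound 4 (0.11 log units; within the scatter) in this assay. Compound 4 is expected at 22 mL.min-1.g-1, within a range from 9 mL.min-1.g-1 to 55 mL.min-1.g-1.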

Compound 4, intrinsic clearance in microsomes: < 14 mL.min-1.g-1
Compound 4 gave a limit, no number (the forecaster's own chance of this, stated with the estimate: 5%); at least 1.5-fold (0.19 log units) between middle value and limit.
By their numbers in this assay, from the lowest: compounds 3, 2 and 1 (each within the scatter of the next). At a limit, below all of these: compound 4.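

In this assay, compound 4 gives a limit, not a number: the limit of < 14 mL.min-1.g-1 in this assay, at which 1 of the 4 values shown sits. For the compounds shown here, its step against the thiophene compound, an at least 2.0-fold lower number from compound 1 to compound 4 (0.31 log units; beyond the scatter), is the first at this position to pass beyond the scatter, although an at least 1.2-fold lower number from compound 3 to compound 4 (0.08 log units; that floor lies within the scatter) and an at least 1.7-fold lower number from compound 2 to compound 4 (0.25 log units; that floor lies within the scatter) have floors that remain within it. The position therefore accepts 1H-indol-2-yl, with its second ring and hydrogen-bond donor, without any sign of faster removal, and the exchange of aryl groups here can produce a step larger than the scatter.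

The limit leaves the full size of all these steps unknown. The compounds shown also cannot separate the contribution of the indole's ring hydrogen from that of its second ring, a question that a 1-methylindol-2-yl or a pyrrol-2-yl group at this position would address.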